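Working notes: chloro for bromo on compound 3

The source may report more compounds than this note shows. Statements on the series, on what has been measured and on what is new or still open speak of the compounds shown alone.

Measured so far in a functional assay on HepG2 cells (Homo sapiens) for antiproliferative activity, read by MTT assay, with a stated time of 48 h; on this read-out higher numbers stand for weaker inhibition and lower numbers for stronger inhibition:
compound 1, `CCOc1ccc(C(=O)/C=C/c2c(/C=C/c3ccc(OC)cc3)cc(OC)cc2OC)cc1`, 8 ug/mL
compound 2, `CCCCCCOc1ccc(C(=O)/C=C/c2c(/C=C/c3ccc(OC)cc3)cc(OC)cc2OC)cc1`, 16.2 ug/mL
compound 3, `COc1ccc(/C=C/c2cc(OC)cc(OC)c2/C=C/C(=O)c2cccc(Br)c2)cc1`, 13 ug/mL

Compound 3 stands second highest of the three numbers; its nearest is compound 2, within the scatter, and its furthest is compound 1, also within the scatter. Compound 4, `COc1ccc(/C=C/c2cc(OC)cc(OC)c2/C=C/C(=O)c2cccc(Cl)c2)cc1`, differs from compound 3 by chloro in place of bromo on an aromatic carbon, meta to a large group. Among the compounds with values here, no measured step exchanges one halogen for another. The step of a 1.6-fold higher number from compound 1 to compound 3 (0.21 log units; within the scatter) replaced the whole 4-ethoxyphenyl with 3-bromophenyl and stayed within the scatter; the step of a 2.0-fold higher number from compound 1 to compound 2 (0.31 log units; beyond the scatter) concerns the other end of the molecule. Within the data shown here, with no matching step to draw on, no step beyond the scatter is expected in this assay: no change at the digits printed from compound 3 to compound 4 (within the scatter). Compound 4 is therefore estimated at 13 ug/mL, within 6.5 ug/mL to 26 ug/mL.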

Compound 4, half-maximal inhibitory concentration: 9.5 ug/mL
Beside the measured number, compound 4's estimate is 1.4-fold (0.14 log units) above it; low and high end bracket the measured number.
By their numbers in this assay, from the lowest: compounds 1, 4, 3 and 2 (each within the scatter of the next, the first and the last beyond it).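

In this assay the only halogen exchange shown, on an aromatic carbon meta to a large group, gives a 1.4-fold lower number from compound 3 to compound 4 (0.14 log units; within the scatter) and does not tell chloro from bromo at this place. Exchanging the whole group on the carbonyl carbon gives a 1.2-fold higher number from compound 1 to compound 4 (0.07 log units; within the scatter) and so does not tell 3-chlorophenyl from 4-ethoxyphenyl. No supporting data bear on these results.

Still open, as far as these compounds go, is whether an amine or a carboxylic acid at this place would give a step beyond the scatter. Also open, from the compounds shown here alone, is whether fluoro or iodo would stay as close to chloro and bromo.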